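This account rests on a few compounds, and the source may have more. Where it says the series, first, only, none or still open, it means among the compounds named here.

Measured so far in an assay on isolated protein for agonist activity at Free fatty acid receptor 1 (Homo sapiens); on this read-out higher numbers stand for an effect only at larger amounts of compound and lower numbers for an effect already at smaller amounts:
compound 1, `CC#CC(CC(=O)O)c1ccc(OCc2ccc3nc(-c4ccc(F)cc4F)cn3c2)cc1`: 825 nM
compound 2, `CC#CC(CC(=O)O)c1ccc(OCc2ccc3nc(-c4ccccc4F)cn3c2)cc1`: 583 nM
compound 3, `CC#CC(CC(=O)O)c1ccc(OCc2ccn3cc(-c4ccc(F)cc4F)nc3c2)cc1`: 792 nM

Compound 1 and compound 2 share one core and differ in a single place, (hydrogen in place of fluoro on an aromatic carbon); in this assay this gives a 1.4-fold lower number from compound 1 to compound 2 (0.15 log units; within the scatter). Compound 3 carries the same atoms as compound 1 joined differently; the difference between the two cores is not broken down here, and the two values lie within the scatter of each other. Compound 4, `CC#CC(CC(=O)O)c1ccc(OCc2ccn3cc(-c4ccc(F)cc4)nc3c2)cc1`, is not yet measured and stands to compound 3 as compound 2 stands to compound 1: hydrogen in place of fluoro on an aromatic carbon. The place is not the same word for word: in compound 1 the leaving fluoro is para to a large group, in compound 3 it is ortho to a large group, while both are meta to a fluoro group, so this is the same kind of change rather than the same change. In this assay the expected step is a 1.3-fold lower number from compound 3 to compound 4 (0.12 log units; within the scatter), set beside a 1.4-fold lower number from compound 1 to compound 2 (0.15 log units; within the scatter), and it rests on that single earlier step, which lies within the scatter. Compound 4 is therefore estimated at 600 nM, between 300 nM and 1200 nM.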

Compound 4, half-maximal effective concentration: 783 nM
Estimate against measurement, compound 4: 1.3-fold (0.12 log units) below; low and high end bracket the measured number.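

In this assay, going from 2,4-difluorophenyl to 4-fluorophenyl on the core of compound 3 gives a 1.0-fold lower number from compound 3 to compound 4 (0.00 log units; within the scatter). Set beside the earlier step, this kind of change reads alike on both cores: the same change on two cores in this assay, a 1.4-fold lower number (0.15 log units; within the scatter) from compound 1 to compound 2 and a 1.0-fold lower number (0.00 log units; within the scatter) from compound 3 to compound 4, 1.4-fold (0.15 log units) apart, within the scatter of two such steps. Among the compounds shown here, this shows only that the change gives no step distinguishable from the scatter on either core; it does not show that the fluoro never matters, as each core offers a single pair, and the fluoro leaving compound 1 and the one leaving compound 3 do not sit at the same place on the ring.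

As far as these compounds go, all four compounds carry at least one fluoro on the phenyl ring, so the unsubstituted phenyl on either core remains open, as do a chloro, methoxy or nitrile group there. Also open, from the compounds shown here alone, is whether an amide or a tetrazole in place of the carboxylic acid would leave the read-out in this assay within the same narrow range.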